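The compounds below may be only part of what the source reports. "The series", "measured", "known", "first", "only" and "open" are said of these compounds alone.

In a functional assay on Lu cells (Homo sapiens) for antiproliferative activity (a higher number here means a weaker inhibitor, a lower number a stronger inhibitor), compound 1 `COc1ccccc1/C=C/C(=O)c1ccc(OCCn2cc(CN3C(=O)/C=C/C(C)(C)C/C=C(\C)CC/C=C/3C)nn2)cc1O` gives 2.4 ug/mL. Compound 2 `COc1cc(/C=C/C(=O)c2ccc(OCCn3cc(CN4C(=O)/C=C/C(C)(C)C/C=C(\C)CC/C=C/4C)nn3)cc2O)cc(OC)c1OC` differs from compound 1 by one change, (3,4,5-trimethoxyphenyl in place of 2-methoxyphenyl on a double-bonded chain carbon bound to a double-bonded chain carbon), and in this assay compound 2 gives 1.28 ug/mL, a step of a 1.9-fold lower number from compound 1 to compound 2 (0.27 log units; within the scatter). Compound 3 `COc1ccccc1/C=C/C(=O)c1ccc(OCCCN2C(=O)/C=C/C(C)(C)C/C=C(\C)CC/C=C/2C)cc1` has another core; how the core of compound 3 differs from the core of compound 1 is not broken down here. In this assay compound 3 gives 2.82 ug/mL. Compound 4 `COc1cc(/C=C/C(=O)c2ccc(OCCCN3C(=O)/C=C/C(C)(C)C/C=C(\C)CC/C=C/3C)cc2)cc(OC)c1OC` stands to compound 3 as compound 2 stands to compound 1, carrying (3,4,5-trimethoxyphenyl in place of 2-methoxyphenyl on a double-bonded chain carbon bound to a double-bonded chain carbon), the same change at the same place. Resting on a 1.9-fold lower number from compound 1 to compound 2 (0.27 log units; within the scatter), the step expected here is a 1.9-fold lower number from compound 3 to compound 4 (0.27 log units; within the scatter), a modest one. Compound 4 is thus expected to come in near 1.5 ug/mL, with a range from 0.7 ug/mL to 3 ug/mL.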

Compound 4, half-maximal inhibitory concentration: 1.01 ug/mL
The estimate for compound 4 lay 1.5-fold (0.17 log units) above the measured number, and the stated range covers the measured number.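

On the core of compound 3, 3,4,5-trimethoxyphenyl in place of 2-methoxyphenyl gives a 2.8-fold lower number from compound 3 to compound 4 (0.45 log units; beyond the scatter) in this assay. The change lowers the number on both cores, and the two steps cannot be told apart: the same change on two cores in this assay, a 1.9-fold lower number (0.27 log units; within the scatter) from compound 1 to compound 2 and a 2.8-fold lower number (0.45 log units; beyond the scatter) from compound 3 to compound 4, 1.5-fold (0.17 log units) apart, within the scatter of two such steps. Among the compounds shown here, this supports carrying the change between these two cores in this assay, but with only two pairs it does not show that the step would hold on any other core, and the earlier step alone lies within the scatter.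

The compounds shown leave open how an amine or a carboxylic acid would fare in place of the methoxy groups on that phenyl. They also leave open whether the step would persist with a longer chain joining the shared parts of these cores.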